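Fluoro in place of trifluoromethyl: expectation for compound 4

A few compounds are considered here, and "the series" means these few. Any claim that something is new, unique, unknown or untested is made for them only; others in the source may bear on it.

Measured so far:
Compound 1 `O=c1ccc(-c2ccc3cn[nH]c3c2)cn1Cc1cccc(C(F)(F)F)c1` gives 40 nM in an assay for inhibition of MAP kinase-interacting serine/threonine-protein kinase 1 (Homo sapiens), read by luminescence and ADP-Glo, with a stated time of 2 h; a lower number here means a stronger inhibitor, a higher number a weaker inhibitor.
Compound 2 `Cn1cc2ccc(-c3ccc(=O)n(Cc4ccccc4)c3)cc2n1` gives only a limit in this assay, > 2000 nM.
Compound 3 `Nc1n[nH]c2cc(-c3ccc(=O)n(Cc4cccc(C(F)(F)F)c4)c3)ccc12` gives 56 nM in this assay.

Compound 1 stands lowest of the two numbers; compound 3 sits close, a 1.4-fold higher number from compound 1 to compound 3 (0.15 log units; within the scatter), so the two are not separated. Among the compounds with values here, compound 2 differs from compound 1 in more than one place and is a limit, so it carries no single step.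

Compound 4 `O=c1ccc(-c2ccc3cn[nH]c3c2)cn1Cc1cccc(F)c1` differs from compound 1 by fluoro in place of trifluoromethyl on an aromatic carbon. Within the data shown here, no measured step covers this change; the one measured step, from compound 1 to compound 3, concerns another position and lies within the scatter. A modest rise is expected, a 3.0-fold higher number from compound 1 to compound 4 (0.48 log units; beyond the scatter). Compound 4 is estimated at 120 nM, between 40 nM and 400 nM.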

Compound 4, half-maximal inhibitory concentration: 74 nM
Compound 4: the middle estimate sits 1.6-fold (0.21 log units) above what was measured; the measured number falls inside the stated range.
By their numbers in this assay, from the lowest: compounds 1, 3 and 4 (each within the scatter of the next). At a limit, above all of these: compound 2.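

In this assay, fluoro in place of trifluoromethyl gives a 1.9-fold higher number from compound 1 to compound 4 (0.27 log units; within the scatter), so the two groups are not separated at this place on the shared core. Trifluoromethyl is therefore not required there for a number of this order, a reading that the earlier step, which concerned another position, could not give. Nothing measured here offers a reason for this step.

On these data alone, whether this place needs any group at all remains open. Also open, as far as these compounds go, is how a methoxy group, a nitrile or a carboxylic acid would read there.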